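Inverting one ring stereocentre in a weakly active series

The compounds below may be only part of what the source reports. "The series", "measured", "known", "first", "only" and "open" are said of these compounds alone.

Compound 1 `CC(=O)Oc1cc2c(CC[C@H]3OC(C)(C)OC3(C)C)c(C)ccc2cc1C(C)C` gives 28900 nM
Compound 2 `Cc1ccc2cc(C(C)C)c(O)cc2c1CC[C@@H]1OC(C)(C)OC1(C)C` gives 26200 nM

In a functional assay on A549 cells (Homo sapiens) for antiproliferative activity, read by sulforhodamine B assay, with a stated time of 72 h (a higher number here means a weaker inhibitor, a lower number a stronger inhibitor), compound 2 gives 26200 nM and lies within the scatter of compound 1 at 28900 nM in the same read-out. Compound 3 `Cc1ccc2cc(C(C)C)c(O)cc2c1CC[C@H]1OC(C)(C)OC1(C)C` has not yet been measured. Against compound 2 the change is this: the two compounds have the same atoms and bonds and differ only in configuration as drawn: 1 of 1 stereo elements differ; a stereocentre at a saturated ring carbon is drawn S in compound 2 and R in compound 3 and nothing more. For the measured compounds named here, no measured pair shows a change of this kind, so no shift beyond the scatter is expected in this assay for now. The estimate means a 1.0-fold lower number from compound 2 to compound 3 (0.02 log units; within the scatter) as the expected step. Compound 3 is estimated at 25000 nM with 12000 nM to 50000 nM as the expected range.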

Compound 3, half-maximal inhibitory concentration: 23500 nM
Compound 3: the middle estimate sits 1.1-fold (0.03 log units) above what was measured; the range from low to high includes it.
By their numbers in this assay, from the lowest: compounds 3, 2 and 1 (each within the scatter of the next).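

In this assay, inverting the stereocentre at a saturated ring carbon gives a 1.1-fold lower number from compound 2 to compound 3 (0.05 log units; within the scatter), so neither drawn configuration separates from the other in this read-out, and the comparison isolates that one centre: the fact that compounds 2 and 3 differ only in the configuration as drawn. Hydrogen in place of acetyl on an oxygen on an aromatic ring gives a 1.2-fold lower number from compound 1 to compound 3 (0.09 log units; within the scatter), so this change also stays inside the scatter.

Still open, as far as these compounds go, is whether the configuration would matter in a compound carrying an amine or a carboxylic acid on the shared core.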